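Removing One Bromine from a Brominated Diphenyl Ether

The source may hold more compounds than are shown below. What is called first, only, known or untested is meant among the compounds shown, and "the series" means these compounds.

Three brominated diphenyl ethers have been tested in an ADME assay on NBT-T2 cells (Rattus norvegicus) for cytotoxicity, read by MTT assay; on this read-out higher numbers stand for weaker inhibition and lower numbers for stronger inhibition. Compound 1 `Oc1ccccc1Oc1c(O)cc(Br)cc1Br` gives only a limit of the assay, > 15 ug/mL. Compound 2 `Oc1cc(Br)ccc1Oc1cc(Br)cc(Br)c1O` gives 8.5 ug/mL. Compound 3 `COc1c(Br)cc(Br)cc1Oc1c(O)c(Br)c(Br)c(Br)c1Br` likewise reaches only a limit, > 15 ug/mL. It therefore stands at the weak end of the values shown, sharing the limit of > 15 ug/mL in this assay, at which 2 of the 3 values shown sit, with compound 1. Compound 4 `COc1c(Br)cc(Br)cc1Oc1c(O)cc(Br)c(Br)c1Br` differs from compound 3 by hydrogen in place of bromo on an aromatic carbon. For the measured compounds named here, no step between measured compounds is available to gauge this change, so any expectation rests on the standing of compound 3 alone. The step expected here, a step that the limit leaves unreadable from compound 3 to compound 4, is small and within the scatter. Compound 4 is thus estimated at 18 ug/mL, in a range from 9 ug/mL to 40 ug/mL.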

Compound 4, half-maximal inhibitory concentration: 2.8 ug/mL
For compound 4 the middle estimate is 6.4-fold (0.81 log units) above the measured one; the whole stated range lies above it.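

In this assay, hydrogen in place of bromo on this aromatic carbon, ortho to a hydroxy group, gives an at least 5.3-fold lower number from compound 3 to compound 4 (0.72 log units; beyond the scatter). For the compounds shown here, this is the first comparison of compounds differing in one place, and it shows that this single bromine matters: losing it moves the read-out beyond the scatter, towards stronger inhibition. As far as these compounds go, the full size of the step stays unknown, as compound 3 gives only a limit: the limit of > 15 ug/mL in this assay, at which 2 of the 4 values shown sit.

One pair cannot show whether the same change acts alike on other brominated diphenyl ethers. From the compounds shown here alone, how an amine or a carboxylic acid would read at this position also remains open.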